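A few compounds are considered here, and "the series" means these few. Any claim that something is new, unique, unknown or untested is made for them only; others in the source may bear on it.

Three compounds have been measured in an ADME assay for permeability, using PAMPA, with a stated time of 30 min, at pH 7.4; on this read-out higher numbers stand for higher permeability and lower numbers for lower permeability:

- compound 1, `COc1ccc(-c2ccc3c(NCCCNCc4cccc(OC)c4O)ccnc3c2)cc1`: 237 10^-6 cm/s
- compound 2, `CC(C)(C)c1ccc(Oc2ccc3c(NCCCNCc4ccco4)ccnc3c2)cc1`: 317 10^-6 cm/s
- compound 3, `COc1ccc(Oc2ccc3c(NCCCNCc4cc(F)ccc4OC)ccnc3c2)cc1`: 317 10^-6 cm/s

On these numbers compound 2 and compound 3 give the same value at the digits shown, and compound 1 lies within the usual scatter of both, so the three measured compounds cannot be told apart in this assay. All three share the same core and differ only in the groups attached to it.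

Compound 4, `Clc1ccc(Oc2ccc3c(NCCCNCc4ccco4)ccnc3c2)cc1`, has not yet been measured. It differs from compound 2 in one place: chloro in place of tert-butyl on an aromatic carbon. Among the compounds with values here, no measured pair shows this exact change, so there is no step to lean on. Given that the three measured numbers sit so close together, the expectation for compound 4 is a step from compound 2 that stays within the scatter, with no direction that can be called. The expected step is a 1.1-fold lower number from compound 2 to compound 4 (0.05 log units; within the scatter). For compound 4 the estimated value in this assay is 280 10^-6 cm/s, with a range from 170 10^-6 cm/s to 430 10^-6 cm/s.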

Compound 4, apparent permeability: 317 10^-6 cm/s
Compound 4: the middle estimate sits 1.1-fold (0.05 log units) below what was measured; low and high end bracket the measured number.
By their numbers in this assay, from the lowest: compounds 1, 2, 3 and 4 (each within the scatter of the next).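

Within the data shown here, this is the first pair in the set that differs in one place, so the first direct reading of a change at this position: in this assay putting chloro in place of tert-butyl gives no change at the digits printed from compound 2 to compound 4 (within the scatter) and so leaves the number unmoved. Here 4-(tert-butyl)phenyl and 4-chlorophenyl cannot be told apart, even though four carbon atoms leave and a single chlorine atom enters on the aromatic carbon. Nothing measured here explains why the exchange leaves the read-out where it was.

As far as these compounds go, whether the position stays this undemanding with an amine, a carboxylic acid or a longer chain in that place remains open. This is also a single pair, so it cannot show whether the same exchange would read alike with a different group at the far end of the side chain.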